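Second chloro on the anilino ring of compound 2

A few compounds are considered here, and "the series" means these few. Any claim that something is new, unique, unknown or untested is made for them only; others in the source may bear on it.

The series shares one core carrying an anilino group; compound 1 `C#CCSc1nc(Nc2ccccc2Cl)c2ccncc2n1` holds a 2-chlorophenyl, compound 2 `C#CCSc1nc(Nc2ccc(Cl)cc2)c2ccncc2n1` a 4-chlorophenyl and compound 3 `C#CCSc1nc(Nc2ccc(Br)cc2)c2ccncc2n1` a 4-bromophenyl. In a functional assay on MGC-803 cells (Homo sapiens) for inhibition, read by MTT assay, with a stated time of 72 h (on this read-out higher numbers stand for weaker inhibition and lower numbers for stronger inhibition), compound 1 gives 27600 nM, compound 2 gives 16400 nM and compound 3 gives 26000 nM. Compound 2 shows the lowest of the three numbers, but a 1.7-fold lower number from compound 1 to compound 2 (0.23 log units; within the scatter) and a 1.6-fold higher number from compound 2 to compound 3 (0.20 log units; within the scatter) are both within the scatter, so no ordering can be drawn.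

Compound 4 `C#CCSc1nc(Nc2ccc(Cl)cc2Cl)c2ccncc2n1` differs from compound 2 by chloro in place of hydrogen on an aromatic carbon. For the measured compounds named here, no measured pair adds a second halogen; the nearest evidence is the move of the single chloro between positions, a 1.7-fold lower number from compound 1 to compound 2 (0.23 log units; within the scatter), and the swap of halogen, a 1.6-fold higher number from compound 2 to compound 3 (0.20 log units; within the scatter), both flat. On that basis little change beyond the scatter is expected, with a 1.1-fold lower number from compound 2 to compound 4 (0.04 log units; within the scatter) as the expected step. The number for compound 4 in this assay is therefore estimated at 15000 nM, within a range of 5000 nM to 45000 nM.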

Compound 4, half-maximal inhibitory concentration: 25500 nM
Beside the measured number, compound 4's estimate is 1.7-fold (0.23 log units) below it; measured number inside the range.
By their numbers in this assay, from the lowest: compounds 2, 4, 3 and 1 (each within the scatter of the next).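

In this assay, for the compounds shown here, a chloro on the aromatic carbon ortho to a large group and meta to the chloro group of compound 2 adds a second halogen to the anilino ring for the first time, giving a 1.6-fold higher number from compound 2 to compound 4 (0.19 log units; within the scatter) and no step that can be read. From the other single-chloro compound, the addition gives a 1.1-fold lower number from compound 1 to compound 4 (0.03 log units; within the scatter) and so the two-chloro ring of compound 4 is not told apart from either parent, and this position accepts a second chloro without a step beyond the scatter. No measurement at hand bears on why the number behaves this way.

On these data alone, every compound here carries only halogen on the anilino ring, so it stays open whether an amine or a carboxylic acid at this position would shift the number beyond the scatter. The same question stands for a longer chain on the sulfur of the shared core.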